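Trimming the Side Chain of an Oxytocin Receptor Antagonist

The source may hold more compounds than are shown below. What is called first, only, known or untested is meant among the compounds shown, and "the series" means these compounds.

Of the compounds shown here, two have been measured in a functional assay on HEK293 cells for antagonist activity at Oxytocin receptor (Homo sapiens), read by calcium flux, with a stated time of 10 min, in the presence of a further agent that is not named here; a lower number here means a stronger inhibitor, a higher number a weaker inhibitor. Compound 1 `COCc1nnc(C2CCN(Cc3ccc(F)cc3Cl)CC2)n1-c1ccc(OC)nc1` is the weaker of the pair: in this assay compound 1 gives 2790 nM. Compound 2 `COc1ccc(-n2c(COCCF)nnc2N2C[C@@H]3C[C@]3(c3ccc(F)cc3Cl)C2)cn1`, built on a different core, gives 44 nM in this assay, the lowest of the two numbers, and its gap to compound 1 lies well beyond the scatter of repeated measurements.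

Compound 3 `COc1ccc(-n2c(C(F)F)nnc2N2C[C@@H]3C[C@]3(c3ccc(F)cc3Cl)C2)cn1` has not yet been measured. It differs from compound 2 in one place: difluoromethyl in place of (2-fluoroethoxy)methyl on an aromatic carbon. Among the compounds with values here, no measured pair shows this particular change, so there is no direct precedent for its size. The side chain shrinks and loses its single hydrogen-bond acceptor, while the rest of compound 2 stays intact. The step of a 1.7-fold higher number from compound 2 to compound 3 (0.23 log units; within the scatter) is expected to be modest, most likely a slight loss within or near the usual scatter. Compound 3 is therefore estimated to give 75 nM in this assay, with a plausible range from 20 nM to 280 nM.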

Compound 3, half-maximal inhibitory concentration: 52 nM
The estimate for compound 3 lay 1.4-fold (0.16 log units) above the measured number, and the stated range covers the measured number.
By their numbers in this assay, from the lowest: compounds 2 and 3 (each within the scatter of the next); then compound 1.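

Replacing (2-fluoroethoxy)methyl with difluoromethyl on this aromatic carbon gives a 1.2-fold higher number from compound 2 to compound 3 (0.07 log units; within the scatter) in this assay, so the two compounds cannot be told apart here. In this pair, the chain with 5 heavy atoms and 1 hydrogen-bond acceptor can give way to a group with 3 heavy atoms and 0 hydrogen-bond acceptors without a readable change in the number. Nothing available explains why these two different groups give such similar results.

One pair cannot show how much variety this position accepts, and an amine, a carboxylic acid or a longer chain on the same carbon could give quite different numbers. As far as these compounds go, it also remains open whether the same swap would give a similar result on a different core.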